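Aryl amide series: working notes on growth inhibition

A few compounds are considered here, and "the series" means these few. Any claim that something is new, unique, unknown or untested is made for them only; others in the source may bear on it.

- compound 1 `CN(C)C(=O)c1cc2cnc(Nc3ccc(NC(=O)C4(C(=O)Nc5cccc(F)c5)CC4)cc3)nc2n1C1CCCC1` 91.8%
- compound 2 `CN(C)C(=O)c1cc2cnc(Nc3ccc(NC(=O)C4(C(=O)Nc5ccc(Br)cc5)CC4)cc3)nc2n1C1CCCC1` 90.3%

In a functional assay on A549 cells (Homo sapiens) for inhibition, read by CCK-8 assay, with a stated time of 72 h, tested at 10 uM (on this read-out lower numbers stand for less inhibition of growth and higher numbers for more inhibition of growth at the one concentration tested), compound 2 gives 90.3% and compound 1 gives 91.8%, two values within the scatter of each other. Compound 3 `CN(C)C(=O)c1cc2cnc(Nc3ccc(NC(=O)C4(C(=O)Nc5ccc(Cl)c(C(F)(F)F)c5)CC4)cc3)nc2n1C1CCCC1` is the next to be read. It carries 4-chloro-3-(trifluoromethyl)phenyl in place of 4-bromophenyl on an amide-type nitrogen. Going by the values given here, one measured step bears on this change, an exchange of aryl groups at the same nitrogen: a number 1.5 percentage points lower from compound 1 to compound 2 (within the scatter), which stays within the scatter. Among the compounds with values here, no measured compound yet carries the entering group, so this support is thin. No step beyond the scatter is expected in this assay. The expected change is a number 1.3 percentage points lower from compound 2 to compound 3 (within the scatter), in no firm direction. For compound 3 the estimated value is 89%, with an expected range of 78% to 97%.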

Compound 3, percent growth inhibition at one concentration: 88.1%
Estimate against measurement, compound 3: 0.9 percentage points above; low and high end bracket the measured number.
By their numbers in this assay, from the lowest: compounds 3, 2 and 1 (each within the scatter of the next).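

In this assay, the aryl group on the amide-type nitrogen can grow to 4-chloro-3-(trifluoromethyl)phenyl, with 11 heavy atoms against 7 in 4-bromophenyl, and the number moves only within the scatter (a number 2.2 percentage points lower from compound 2 to compound 3 (within the scatter); a number 3.7 percentage points lower from compound 1 to compound 3 (within the scatter)). The entering group also brings a chlorine and a trifluoromethyl group together on one phenyl ring, yet the three aryl groups shown remain inseparable at this single concentration. No evidence is available that would explain this flat result.

The compounds shown leave open whether the flat response extends to an aryl ring containing nitrogen, such as pyridine, or to a phenyl ring bearing a carboxylic acid or an amine. They also leave open whether the three compounds would separate at lower concentrations.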